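A few compounds are considered here, and "the series" means these few. Any claim that something is new, unique, unknown or untested is made for them only; others in the source may bear on it.

Working notes on the series in a functional assay on HCT-15 cells (Homo sapiens) for antiproliferative activity, read by sulforhodamine B assay; a lower number here means a stronger inhibitor of growth, a higher number a weaker inhibitor of growth. In this assay compound 1 `O=C(/C=C/c1ccc(O)cc1)c1c(O)cccc1OCC1CCCCC1` gives > 30000 nM, which is a limit of the assay and not a number. Compound 2 `CCCCOc1cccc(O)c1C(=O)/C=C/c1ccc(O)cc1` gives > 30000 nM, likewise only a limit, and so it stands at the same limit of > 30000 nM in this assay, at which 2 of the 2 values shown sit, with no number to place it. Compound 3 `CCC(CC)COc1cccc(O)c1C(=O)/C=C/c1ccc(O)cc1` differs from compound 2 by ethyl in place of hydrogen on a saturated chain carbon bound to two saturated chain carbons, so that butoxy becomes 2-ethylbutoxy. Going by the values given here, the only measured change of this chain, a step that the two limits leave unreadable from compound 1 to compound 2, has no readable size, so it offers no magnitude to carry over and gives no sign of any gain in this assay. No shift beyond the scatter is therefore expected, and no direction can be named, giving an expected a number no higher from compound 2 to compound 3 (the limit leaves the size open). Compound 3 is estimated at 30000 nM, with an expected range of 12000 nM to 60000 nM, and a report as a limit is the likeliest outcome.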

Compound 3, concentration for 50% growth inhibition: 3420 nM
Compound 3: middle estimate off by 8.8-fold (0.94 log units), on the high side; measured number outside the range, below it.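

In this assay the ether chain now proves able to move the read-out: ethyl in place of hydrogen on a saturated chain carbon bound to two saturated chain carbons, which turns butoxy into 2-ethylbutoxy, gives an at least 8.7-fold lower number from compound 2 to compound 3 (0.94 log units; beyond the scatter). The change at this carbon is not a matter of added carbon alone, since pentan-3-yl in place of cyclohexyl gives an at least 8.7-fold lower number from compound 1 to compound 3 (0.94 log units; beyond the scatter), and the open chain thus separates from the ring on the same carbon bound to the oxygen. Only compound 3 gives a number, and the other two compounds stay at a limit: the limit of > 30000 nM in this assay, at which 2 of the 3 values shown sit.

On these data alone, both steps start from limits, so their true sizes remain open. As far as these compounds go, whether a longer chain such as 2-propylpentyloxy, or an amine at the chain end, lowers the number further also remains open.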